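This account rests on a few compounds, and the source may have more. Where it says the series, first, only, none or still open, it means among the compounds named here.

Working notes on the series.

Compound 1 `COC(=O)[C@@]1(C)CCC=C2[C@@H]1CC[C@@H](C)[C@]2(C)Cc1c[nH]c2ccc(C)cc12` serves as the first reference. In a functional assay on SW1573 cells (Homo sapiens) for inhibition, read by sulforhodamine B assay, with a stated time of 48 h (on this read-out higher numbers stand for weaker inhibition of growth and lower numbers for stronger inhibition of growth), compound 1 gives 15000 nM. Compound 2 `COC(=O)[C@@]1(C)CCC=C2[C@@H]1CC[C@@H](C)[C@]2(C)Cc1c[nH]c2ccc(Br)cc12` carries the change (bromo in place of methyl on an aromatic carbon), and in this assay compound 2 gives 12000 nM. The step this change made is a 1.3-fold lower number from compound 1 to compound 2 (0.10 log units; within the scatter), so the two values show nothing that can be told apart by this read-out.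

Compound 3 `COC(=O)[C@@]1(C)CC[C@@H]2C3=C1CC[C@@H](C)[C@]3(C)Cc1c2[nH]c2ccc(C)cc12` has a different core; the difference between the core of compound 3 and the core of compound 1 is not broken down here. In this assay compound 3 gives 15000 nM, which is level with compound 1 at the digits recorded and within the scatter of compound 2 as well.

Compound 4 `COC(=O)[C@@]1(C)CC[C@@H]2C3=C1CC[C@@H](C)[C@]3(C)Cc1c2[nH]c2ccc(Br)cc12` is not yet measured. It differs from compound 3 by bromo in place of methyl on an aromatic carbon. Going by the values given here, this is the same kind of change as the one from compound 1 to compound 2, not the same change: around the place, the aromatic carbon in compound 1 sits in a fused or bridged system of two rings, whereas in compound 3 it sits in a fused or bridged system of five rings.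

Among the compounds with values here, for compound 4 the expected step in this assay is a 1.3-fold lower number from compound 3 to compound 4 (0.10 log units; within the scatter), beside the earlier step of a 1.3-fold lower number from compound 1 to compound 2 (0.10 log units; within the scatter), because the only measured instance of this kind of change, a 1.3-fold lower number from compound 1 to compound 2 (0.10 log units; within the scatter), stayed within the scatter. The expected value for compound 4 in this assay is therefore 12000 nM. Its expected range runs from 6000 nM to 25000 nM, resting on a single precedent and on the different core.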

Compound 4, concentration for 50% growth inhibition: 12000 nM
For compound 4 middle estimate and measured number coincide at the digits printed; low and high end bracket the measured number.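

In this assay bromo in place of methyl on an aromatic carbon of the core of compound 3 gives a 1.3-fold lower number from compound 3 to compound 4 (0.10 log units; within the scatter). Set beside the earlier step, the change carries from the core of compound 1 to the core of compound 3 with no difference that this read-out can separate: the same change on two cores in this assay, a 1.3-fold lower number (0.10 log units; within the scatter) from compound 1 to compound 2 and a 1.3-fold lower number (0.10 log units; within the scatter) from compound 3 to compound 4, 1.0-fold (0.00 log units) apart, within the scatter of two such steps. This shows that, in these two pairs, the change leaves the number within the scatter on both cores; it does not show that the two cores would also match for a change that gives a step beyond the scatter, nor does it say anything about other pairs of groups at this place.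

The compounds shown leave open whether any group on this aromatic carbon could move the number beyond the scatter on either core, for instance an amine, a carboxylic acid or a longer chain in place of the methyl or bromo. As far as these compounds go, the same ester stands in all four compounds, and what a carboxylic acid or an amide in its place would do on either core also remains open.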